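The source may report more compounds than this note shows. Statements on the series, on what has been measured and on what is new or still open speak of the compounds shown alone.

Compound 1 `CN1CCN(Cc2csc(N)c2C(=O)c2ccc(Cl)cc2)CC1` and compound 2 `Cc1ccc(N2CCN(Cc3csc(N)c3C(=O)c3ccc(Cl)cc3)CC2)cc1` share one core and differ only on an amine nitrogen in a ring. In an assay on CHO cells for displacement of a labelled ligand from adenosine receptor A1 (Homo sapiens) (on this read-out higher numbers stand for weaker binding and lower numbers for tighter binding), compound 1 gives 1.7 nM, and compound 2 gives 1.7 nM; the step of no change at the digits printed from compound 1 to compound 2 (within the scatter) shows that compound 2 stands level with compound 1. Compound 3 `N#Cc1ccc(N2CCN(Cc3csc(N)c3C(=O)c3ccc(Cl)cc3)CC2)cc1` carries cyano in place of methyl on an aromatic carbon. Within the data shown here, no measured step touches the aromatic carbon concerned; the one measured step, no change at the digits printed from compound 1 to compound 2 (within the scatter), bears on another part of the molecule, so it offers only a weak guide. Compound 3 is therefore expected to move by about a 1.2-fold higher number from compound 2 to compound 3 (0.07 log units; within the scatter) in this assay. Compound 3 is estimated at 2 nM, within 0.8 nM to 5 nM.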

Compound 3, dissociation constant: 1.8 nM
The estimate for compound 3 lay 1.1-fold (0.05 log units) above the measured number; the measured number falls inside the stated range.
By their numbers in this assay, from the lowest: compounds 1, 2 and 3 (each within the scatter of the next).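

In this assay, cyano in place of methyl on an aromatic carbon, para to a large group, reads as a 1.1-fold higher number from compound 2 to compound 3 (0.02 log units; within the scatter) and stays within the scatter, even though cyano brings a hydrogen-bond acceptor that methyl lacks. The wider swap on the ring amine nitrogen, 4-cyanophenyl for methyl, reads as a 1.1-fold higher number from compound 1 to compound 3 (0.02 log units; within the scatter) and also stays within the scatter. No evidence at hand accounts for this flat result. The compounds shown leave open whether a carboxylic acid or an amine at this same place would hold that level, and how far the read-out depends on the other parts of the shared core.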